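Lengthening the Acyl Chain of a Ceramide-Like Compound

A few compounds are considered here, and "the series" means these few. Any claim that something is new, unique, unknown or untested is made for them only; others in the source may bear on it.

A pair of measured compounds set the scene. In a functional assay on SUP-T1 cells (Homo sapiens) for cytotoxicity, read by CellTiter-Blue, with a stated time of 24 h (a higher number here means a weaker inhibitor, a lower number a stronger inhibitor), compound 1 `CCCCCCCCCCCCC/C=C/[C@@H](O)[C@H](CO)NC(C)=O` gives 41400 nM; > 200000 nM (2 entries). Going by the values given here, compound 2 `CCCCCC(=O)N[C@@H](CO)[C@H](O)/C=C/CC(CC(C)C)CC(C)C` gives 52900 nM in this assay, the only number recorded for it, while one further entry for compound 2 carries no single number. On the numbers shown, compound 2 and compound 1 sit within the usual scatter of each other, so neither can be ranked ahead of the other.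

Compound 3 `CCCCCCCCCCC(=O)N[C@@H](CO)[C@H](O)/C=C/CC(CC(C)C)CC(C)C` differs from compound 2 in one place: pentyl in place of hydrogen on a saturated chain carbon, five bonds along the chain from a carbonyl carbon. Among the compounds with values here, no measured pair in this set differs in only one place, so the size of such a step has no yardstick here. The step of a 1.8-fold lower number from compound 2 to compound 3 (0.25 log units; within the scatter) is expected to be a modest gain in potency, around the edge of the scatter. Compound 3 is therefore estimated at 30000 nM, with a plausible range from 10000 nM to 90000 nM.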

Compound 3, half-maximal inhibitory concentration: 15500 nM
Compound 3: the middle estimate sits 1.9-fold (0.29 log units) above what was measured, and the stated range covers the measured number.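

Adding pentyl on a saturated chain carbon, five bonds along the chain from a carbonyl carbon, gives the first change in this set whose size can be read: in this assay it produces a 3.4-fold lower number from compound 2 to compound 3 (0.53 log units; beyond the scatter), a modest step but a real one. This place on the chain therefore accepts the added carbons, and for this pair the longer acyl chain goes with stronger activity. The step rests on one number for each compound, and entries in this assay can lie far apart, with one entry for compound 1 being a limit and not a number: the several entries of compound 1 in this assay, 41400 nM; > 200000 nM (2 entries).

Going by these compounds, whether a still longer chain would lower the number further remains open. So does the effect of an amine or a carboxylic acid at this same place.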